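Heptyl-urea series: triazole to methylpyrazole on the para position

The compounds below may be only part of what the source reports. "The series", "measured", "known", "first", "only" and "open" are said of these compounds alone.

The shared core carries a urea bearing a trimethylphenyl group and a substituted cycloalkyl amine, with an arylmethyl arm that varies. In an assay on microsomes from intestine for inhibition of acyl-CoA:cholesterol acyltransferase (Oryctolagus cuniculus) (a higher number here means a weaker inhibitor, a lower number a stronger inhibitor), compound 1 `Cc1cc(C)c(NC(=O)N(Cc2cc(-c3ccccc3)cs2)C2CCCCCC2)c(C)c1` gives 36 nM, compound 3 `Cc1cc(C)c(NC(=O)N(Cc2cccc(-c3cc[nH]n3)c2)C2CCCC2)c(C)c1` gives 22 nM, and compound 2 `Cc1cc(C)c(NC(=O)N(Cc2ccc(-c3n[nH]c(C)n3)cc2)C2CCCCCC2)c(C)c1` gives 120 nM, the highest of the three numbers, beyond the scatter from both of the others.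

Compound 4 `Cc1cc(C)c(NC(=O)N(Cc2ccc(-c3ccnn3C)cc2)C2CCCCCC2)c(C)c1` differs from compound 2 in one place: 1-methyl-1H-pyrazol-5-yl in place of 5-methyl-1H-1,2,4-triazol-3-yl on an aromatic carbon on an aromatic carbon of the six-membered carbon ring, para to a large group. Among the measured compounds shown here, no measured pair shows this change. Since compound 2 stands at 120 nM, the weakest point of the set, a moderate step toward a lower number is expected, a 2.0-fold lower number from compound 2 to compound 4 (0.30 log units; within the scatter). Compound 4 is therefore estimated at 60 nM, with a range from 20 nM to 200 nM.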

Compound 4, half-maximal inhibitory concentration: 24 nM
Compound 4: the middle estimate sits 2.5-fold (0.40 log units) above what was measured; measured number inside the range.
By their numbers in this assay, from the lowest: compounds 3, 4 and 1 (each within the scatter of the next); then compound 2.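

In this assay, among the compounds shown here, 1-methyl-1H-pyrazol-5-yl in place of 5-methyl-1H-1,2,4-triazol-3-yl gives a 5.0-fold lower number from compound 2 to compound 4 (0.70 log units; beyond the scatter), the first one-place comparison in this set. This position, on the six-membered aromatic ring and para to a large group, therefore responds to the identity of the five-membered ring. The change removes the hydrogen-bond donor and swaps a ring nitrogen for carbon together, and nothing available accounts for the step.

The pair cannot separate those two differences. From the compounds shown here alone, how an amine or a carboxylic acid would fare at this position remains open.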